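From Cyano to Diethylcarbamoyl on the Side Chain

A few compounds are considered here, and "the series" means these few. Any claim that something is new, unique, unknown or untested is made for them only; others in the source may bear on it.

For the measured compounds named here, in a functional assay on MCF7 cells (Homo sapiens) for cytotoxicity, read by colorimetric assay and MTT assay (a lower number here means a stronger inhibitor, a higher number a weaker inhibitor), compound 3 (`COc1ccc(-c2cc3c(OC)cc(OC)cc3n(CCC#N)c2=O)cc1`) gives 10000 nM and stands level with compound 1 (`COc1ccc(-c2cc3c(OC)cc(OC)cc3n(CC#N)c2=O)cc1`) at 10000 nM and compound 2 (`COc1ccc(-c2cc3c(OC)cc(OC)cc3n(CCCC#N)c2=O)cc1`) at 10000 nM on the numbers so far. Compound 4 (`CCN(CC)C(=O)CCn1c(=O)c(-c2ccc(OC)cc2)cc2c(OC)cc(OC)cc21`) carries diethylcarbamoyl in place of cyano on a saturated chain carbon, two bonds along the chain from an aromatic nitrogen. Going by the values given here, three measured steps bear on this change, though only indirectly, since each alters the chain and keeps the cyano group. They read (no change at the digits printed from compound 1 to compound 2 (within the scatter)) and (no change at the digits printed from compound 1 to compound 3 (within the scatter)) and (no change at the digits printed from compound 2 to compound 3 (within the scatter)) so none of them leaves the scatter. Among the compounds with values here, no measured step replaces the cyano group itself, which leaves the size of this swap unshown. With nothing pointing either way, no step beyond the scatter is expected in this assay for this swap. The expected step is (no change at the digits printed from compound 3 to compound 4 (within the scatter)) on this reasoning. Compound 4 is estimated at 10000 nM with a wide expected range (3000 nM to 20000 nM).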

Compound 4, half-maximal inhibitory concentration: 10000 nM
For compound 4 middle estimate and measured number coincide at the digits printed, within the range that was stated.
By their numbers in this assay, from the lowest: compounds 1, 2, 3 and 4 (each within the scatter of the next).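

In this assay, for the compounds shown here, the first change to the cyano end itself reads no change at the digits printed from compound 3 to compound 4 (within the scatter), so going from cyano, with 2 heavy atoms and a triple bond, to diethylcarbamoyl, with 7 heavy atoms and a double bond, gives no step beyond the scatter. The comparisons with the other two nitrile side chains read the same, no change at the digits printed from compound 2 to compound 4 (within the scatter) and no change at the digits printed from compound 1 to compound 4 (within the scatter), so across these four compounds neither the end group nor the chain length moves the number. No measurement on hand accounts for this flat reading.

Going by these compounds, whether an amine or a carboxylic acid at the end of the chain would give a different number remains open. So does the effect of replacing a methoxy group on the shared core, since every compound shown keeps that core unchanged.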